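A few compounds are considered here, and "the series" means these few. Any claim that something is new, unique, unknown or untested is made for them only; others in the source may bear on it.

The two measured compounds in a functional assay on CHO cells with adenosine receptor A1 (Homo sapiens) as the target, read by cAMP accumulation and immunoassay, with a stated time of 6 min, tested at 1 uM (on this read-out lower numbers stand for a stronger effect and higher numbers for a weaker effect at the one concentration tested), are compound 1, `Nc1scc(CN2CCN(c3ccncc3)CC2)c1C(=O)c1ccc(Cl)cc1`, and compound 2, `Nc1scc(CN2CCN(c3cccc(F)c3)CC2)c1C(=O)c1cccc(C(F)(F)F)c1`. In this assay compound 1 gives -8.3%, while compound 2 gives -35%. Compound 1 thus stands at the highest of the two numbers, and the gap to compound 2 lies beyond the scatter of the measurement.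

Compound 3, `Nc1scc(CN2CCN(c3cccc(Cl)c3)CC2)c1C(=O)c1ccc(Cl)cc1`, is the compound not yet measured. It differs from compound 1 in one place: 3-chlorophenyl in place of pyridin-4-yl on an amine nitrogen in a ring. Going by the values given here, no pair of measured compounds isolates this change, so the size of its step in this assay is not known from the data. Compound 2, which carries a ring of carbon only at the same amine nitrogen, gives the lower value, so a moderate downward step is expected rather than none at all.

Compound 3 is therefore estimated to give -22% in this assay, within a range from -45% to 2%. The step from compound 1 to compound 3 that this estimate means is a number 13.7 percentage points lower from compound 1 to compound 3 (beyond the scatter).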

Compound 3, a percentage reported as activity, at one concentration (the size of the read-out at that concentration, not a potency): -59%
Compound 3: the middle estimate sits 37 percentage points above what was measured; the measured number lies below the stated range.
By their numbers in this assay, from the lowest: compound 3; then compound 2; then compound 1.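

In this assay the change on the amine nitrogen of the ring with two nitrogens, 3-chlorophenyl in place of pyridin-4-yl, gives a number 50.7 percentage points lower from compound 1 to compound 3 (beyond the scatter) with the rest of the structure unchanged. Going by these compounds alone, this is the first pair that isolates a change at this position, and it shows that the group on this nitrogen can by itself move the read-out by a large amount towards a stronger effect at the one concentration tested. Nothing given here accounts for the size of this step.

The change swaps the ring nitrogen for carbon and adds a chlorine at once, so the compounds shown leave open how much of the step belongs to each. As far as these compounds go, a plain phenyl group or a 3-methoxyphenyl group at this nitrogen would be needed to tell these apart, and how either would read here remains open.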